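The source may hold more compounds than are shown below. What is called first, only, known or untested is meant among the compounds shown, and "the series" means these compounds.

In an ADME assay on cells for inhibition of cytochrome P450 11B1, mitochondrial (Homo sapiens), read by HPLC, with a stated time of 60 min (on this read-out lower numbers stand for stronger inhibition and higher numbers for weaker inhibition), compound 1 `Cc1ncncc1-c1nc2cc(F)c(F)cc2n1C1CC1` gives 4160 nM and compound 2 `CCc1ncncc1-c1nc2cc(F)c(F)cc2n1C1CC1` gives 3330 nM; the two numbers lie within the scatter of each other, so compound 2 stands beside compound 1 rather than apart from it. Among the measured compounds shown here, the only step measured so far, a 1.2-fold lower number from compound 1 to compound 2 (0.10 log units; within the scatter), was small. Compound 3 `CC(C)c1ncncc1-c1nc2cc(F)c(F)cc2n1C1CC1` carries a further change of the same kind, (methyl in place of hydrogen on a saturated chain carbon bound to an aromatic carbon and a saturated chain carbon). Because a 1.2-fold lower number from compound 1 to compound 2 (0.10 log units; within the scatter) stayed within the scatter, the step to compound 3 is expected to be small too, a 1.2-fold lower number from compound 2 to compound 3 (0.08 log units; within the scatter). Compound 3 is estimated in this assay at 2800 nM, with a range from 1400 nM to 5600 nM.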

Compound 3, half-maximal inhibitory concentration: 1910 nM
The estimate for compound 3 lay 1.5-fold (0.17 log units) above the measured number, within the range that was stated.
By their numbers in this assay, from the lowest: compounds 3, 2 and 1 (each within the scatter of the next, the first and the last beyond it).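

The single added methyl gives a 1.7-fold lower number from compound 2 to compound 3 (0.24 log units; within the scatter) and so cannot be read alone. Isopropyl in place of methyl on an aromatic carbon, however, gives a 2.2-fold lower number from compound 1 to compound 3 (0.34 log units; beyond the scatter) and is the first step here to clear the scatter, though only modestly. Nothing measured here bears on why the number moves. 

On these data alone, whether the number keeps falling as this group grows remains open: a tert-butyl group could test that. An amine on the same aromatic carbon would show whether anything other than a plain carbon group is tolerated there.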